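The source may hold more compounds than are shown below. What is called first, only, known or untested is meant among the compounds shown, and "the series" means these compounds.

Measured in an ADME assay on J774 cells (Mus musculus) for cytotoxicity, read by resazurin assay, with a stated time of 72 h; a higher number here means that more compound is tolerated, a lower number that less compound is tolerated:

- Compound 1 `C/C(=N\Nc1nc(C)cs1)c1ccc(Cl)c(Cl)c1`: 33700 nM
- Compound 2 `C/C(=N\Nc1nc(CCl)cs1)c1ccc(Cl)c(Cl)c1`: > 50000 nM, a limit of the assay and not a number
- Compound 3 `C/C(=N\Nc1nc(-c2ccccn2)cs1)c1ccc(Cl)c(Cl)c1`: 10100 nM

Compound 3 carries the lowest number of the series so far, as shown by a 3.3-fold lower number from compound 1 to compound 3 (0.52 log units; beyond the scatter) and by an at least 4.9-fold lower number from compound 2 to compound 3 (0.69 log units; beyond the scatter). Compound 4 `C/C(=N\Nc1nc(-c2ccncc2)cs1)c1ccc(Cl)c(Cl)c1` has the same atoms as compound 3, joined differently, with pyridin-4-yl in place of pyridin-2-yl on an aromatic carbon. For the measured compounds named here, no measured step compares two pyridine attachments. The closest evidence is the replacement of methyl by pyridin-2-yl, a 3.3-fold lower number from compound 1 to compound 3 (0.52 log units; beyond the scatter), and the replacement of chloromethyl by pyridin-2-yl, an at least 4.9-fold lower number from compound 2 to compound 3 (0.69 log units; beyond the scatter). Both exchange a small group for the ring, whereas here the ring stays and only its attachment changes. A step smaller than either is therefore expected in this assay, with none beyond the scatter and no firm direction. The estimated step is a 1.1-fold higher number from compound 3 to compound 4 (0.04 log units; within the scatter). Compound 4 is expected at 11000 nM, with an estimated range of 4500 nM to 27000 nM.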

Compound 4, half-maximal cytotoxic concentration: 39800 nM
For compound 4 the middle estimate is 3.6-fold (0.56 log units) below the measured one; the measured number lies above the stated range.
By their numbers in this assay, from the lowest: compound 3; then compounds 1 and 4 (each within the scatter of the next). At a limit, above all of these: compound 2.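

In this assay, the position on the five-membered aromatic ring is sensitive to how the pyridine ring is attached, not only to whether one is present: with the same atoms, a 3.9-fold higher number from compound 3 to compound 4 (0.60 log units; beyond the scatter). The lower number of compound 3 therefore belongs to pyridin-2-yl and not to every pyridine ring at this place, since a 1.2-fold higher number from compound 1 to compound 4 (0.07 log units; within the scatter) and methyl and pyridin-4-yl cannot be told apart here. Compound 2 gives a limit of the assay and not a number, and an at least 1.2-fold lower number from compound 2 to compound 4 (0.09 log units; that floor lies within the scatter) sets no order between the two: the limit of > 50000 nM in this assay, at which 1 of the 4 values shown sits.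

Going by these compounds, whether pyridin-3-yl or a plain phenyl ring at this place would stand with compound 3 or with compound 4 remains open. So does the effect of an amine on the pyridine ring of compound 3.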